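The compounds below may be only part of what the source reports. "The series", "measured", "known", "first", "only" and "open" are said of these compounds alone.

Measured so far:
Compound 1, `CS(=O)(=O)c1ccc(C(=O)N2CCC(C(=O)N3CCc4ccccc43)CC2)cc1[N+](=O)[O-]`: > 60000 nM.
Compound 2, `CS(=O)(=O)c1ccc(C(=O)N2CCC(C(=O)N3CCC(c4ccccc4)CC3)CC2)cc1[N+](=O)[O-]`: > 60000 nM.
Compound 3, `CS(=O)(=O)c1ccc(C(=O)NCC(=O)N2CCCCC2)cc1[N+](=O)[O-]`: > 60000 nM.

All three were tested in an assay on isolated protein for inhibition of thyroid hormone receptor beta (Homo sapiens), read by fluorescence polarization; on this read-out lower numbers stand for stronger inhibition and higher numbers for weaker inhibition. Compound 1 gives only a limit of the assay there, > 60000 nM, so no number stands for it, just the bound. The same holds for compound 2, which gives the limit > 60000 nM. Compound 3 likewise gives the limit > 60000 nM. In other words, every value shown sits at the limit of > 60000 nM in this assay, at which 3 of the 3 values shown sit, and nothing can be said about order among the three.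

The compound still to be measured is compound 4, `CN1CCN(C(=O)C2CCN(C(=O)c3ccc(S(C)(=O)=O)c([N+](=O)[O-])c3)CC2)CC1`. It differs from compound 1 in one place: 4-methylpiperazin-1-yl in place of 2,3-dihydro-1H-indol-1-yl on a carbonyl carbon. Within the data shown here, since compound 1, compound 2 and compound 3 all share the same core and all sit at the limit, no measured step exists that could show how such an exchange on that carbonyl carbon moves the read-out. With no other guide, the expectation is that compound 4 stays where compound 1 stands, with no step beyond the usual scatter in either direction, and most likely only a limit again.

Compound 4 is therefore estimated at about 60000 nM, with a range from 20000 nM to 200000 nM. The step this estimate implies, a number no higher from compound 1 to compound 4 (the limit leaves the size open), is expected to be no real change.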

Compound 4, half-maximal inhibitory concentration: > 60000 nM
Compound 4 was reported as a limit; the forecaster's own chance of this, stated with the estimate: 85%; the middle value lies on the limit itself.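

Compound 4 gives > 60000 nM, which is a limit of the assay and not a number. No step from compound 1 to compound 4 can be read, as neither compound has a number: the limit of > 60000 nM in this assay, at which 4 of the 4 values shown sit.

The compounds shown leave open whether any group on that carbonyl carbon can bring the shared core to a measurable number in this assay.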